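The compounds below may be only part of what the source reports. "The series", "measured", "known", "first", "only" and "open" are said of these compounds alone.

Compound 1 `COc1ccc(/C=C/C(=O)O)cc1OC(=O)c1nc(C)c(C)nc1C`: in a functional assay on EA.hy 926 cells (Homo sapiens) for cytotoxicity, read by MTT assay, with stated times of 24 h and 12 h, tested at 12.5 uM (a higher number here means a stronger effect of the compound at the concentration tested, a lower number a weaker effect), compound 1 gives 41.3%.
Compound 2 `COc1cc(/C=C/C(=O)O)cc(OC)c1OC(=O)c1nc(C)c(C)nc1C`: in this assay compound 2 gives 5.7%.
Compound 3 `CCOC(=O)/C=C/c1ccc(OC)c(OC(=O)c2nc(C)c(C)nc2C)c1`: in this assay compound 3 gives 26.4%.

Compound 1 and compound 3 share a core and differ by one change, (ethyl in place of hydrogen on an oxygen next to a carbonyl group). In this assay that change gave a number 14.9 percentage points lower from compound 1 to compound 3 (beyond the scatter), a drop that lies beyond the scatter. Compound 2 has a different core from compound 1; how the two cores differ is not broken down here. What the numbers show is that compound 2 sits at the bottom of the three measured values, beyond the scatter from both compound 3 and compound 1.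

Compound 4 `CCOC(=O)/C=C/c1cc(OC)c(OC(=O)c2nc(C)c(C)nc2C)c(OC)c1` has not yet been measured in this assay. It differs from compound 2 by ethyl in place of hydrogen on an oxygen next to a carbonyl group, the same change that leads from compound 1 to compound 3, made at the same place. For the measured compounds named here, compound 4 is expected to give 3%, because a number 14.9 percentage points lower from compound 1 to compound 3 (beyond the scatter) was a fall and nothing among the measured compounds points the other way. The expected step, a number 2.7 percentage points lower from compound 2 to compound 4 (within the scatter), is estimated to be smaller than the one seen earlier, since compound 2 already reads 5.7% and the read-out cannot fall far below that. The expected value of compound 4 is estimated to lie between 0% and 14%. This rests on a single earlier instance of the change and on a different core, so the estimate is loose.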

Compound 4, a percentage reported as activity, at one concentration (the size of the read-out at that concentration, not a potency): 96.6%
Compound 4: the middle estimate sits 93.6 percentage points below what was measured; measured number above the stated range.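

In this assay, ethyl in place of hydrogen on an oxygen next to a carbonyl group gave a number 90.9 percentage points higher from compound 2 to compound 4 (beyond the scatter), and set beside the earlier step, the change carried over from one core to the other in neither direction nor size: the same change on two cores in this assay, a number 14.9 percentage points lower (beyond the scatter) from compound 1 to compound 3 and a number 90.9 percentage points higher (beyond the scatter) from compound 2 to compound 4, 105.8 percentage points apart, beyond the scatter of two such steps

Within these four compounds, then, the outcome of going from carboxy to ethoxycarbonyl depends on the core that carries it, so the step seen on one core gives no safe guide to the step on the other. For the compounds shown here, what this does not show is why the two cores part so sharply, which feature of the core decides the outcome, or what the same change would do on any third core, since only two pairs of compounds stand behind the comparison.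

The compounds shown leave open whether a methyl group, a longer chain such as butyl, or an amide in place of the ethyl ester would follow the fall seen on the core of compound 1 and the rise seen on the core of compound 2. They also leave open whether the gap between the two steps would hold at other concentrations, as each number here is a read-out at a single concentration and not a potency.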